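The source may hold more compounds than are shown below. What is called first, only, known or untested is meant among the compounds shown, and "the series" means these compounds.

Compound 1 `CN(C)/N=C/c1ccc(C2=C(Cl)C(=O)c3ccccc3C2=O)o1` gives 8100 nM in a functional assay on MCF7 cells (Homo sapiens) for cytotoxicity, with a stated time of 48 h; on this read-out lower numbers stand for stronger inhibition of growth and higher numbers for weaker inhibition of growth.
Compound 2 `CN(C)/N=C/c1ccc(-c2c(O)ccc(O)c2C=O)o1` gives 29400 nM in this assay.

Of these two numbers, compound 2 stands highest; its nearest neighbour is compound 1, whose lower number lies beyond the scatter. Compound 3 `O=Cc1ccc(-c2c(O)ccc(O)c2C=O)o1` differs from compound 2 in one place: a group of 2 heavy atoms (1 carbon, 1 oxygen; no ring) in place of a group of 5 heavy atoms (3 carbon, 2 nitrogen; no ring), on an aromatic carbon, in words a group of 2 heavy atoms (1 carbon, 1 oxygen; no ring) in place of a group of 5 heavy atoms (3 carbon, 2 nitrogen; no ring), on an aromatic carbon. Among the compounds with values here, no measured pair shows such a change, so no direction can be read from the data. In this assay the expected step is a 1.2-fold lower number from compound 2 to compound 3 (0.07 log units; within the scatter), not beyond the scatter. Compound 3 is estimated at 25000 nM, with a range from 8000 nM to 80000 nM.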

Compound 3, concentration for 50% growth inhibition: 20300 nM
For compound 3 the middle estimate is 1.2-fold (0.09 log units) above the measured one, and the stated range covers the measured number.
By their numbers in this assay, from the lowest: compound 1; then compounds 3 and 2 (each within the scatter of the next).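

In this assay, putting formyl in place of the group of 5 heavy atoms, on an aromatic carbon of a five-membered aromatic ring with 1 oxygen, gives a 1.4-fold lower number from compound 2 to compound 3 (0.16 log units; within the scatter) and so leaves the two compounds indistinguishable on this read-out. This position therefore accepts either group, the smaller formyl included, without a step beyond the scatter. Nothing available explains this outcome.

As far as these compounds go, whether an amine, a carboxylic acid or a longer chain at this place would give a step beyond the scatter stays open. So does whether the same change would give a similar step on the core of compound 1.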